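Amino in place of chloro: an expected step

A few compounds are considered here, and "the series" means these few. Any claim that something is new, unique, unknown or untested is made for them only; others in the source may bear on it.

Within the data shown here, in a functional assay on KYSE-450 cells (Homo sapiens) for inhibition, read by MTT assay, with a stated time of 48 h (a higher number here means a weaker inhibitor, a lower number a stronger inhibitor), compound 1 `COc1ccc(CNc2cc(OC)c(OC)c(OC)c2)cc1Cl` gives 47800 nM and stands within the scatter of the only other measured compound: compound 2 `COc1ccc(N(Cc2cc(OC)c(OC)c(OC)c2)C(=O)CCl)cc1O` gives 29800 nM and the two cannot be ranked. Among the measured compounds shown here, compound 3 `COc1ccc(CNc2cc(OC)c(OC)c(OC)c2)cc1N` keeps the core of compound 1 and carries amino in place of chloro on an aromatic carbon, ortho to a methoxy group amino in place of chloro on an aromatic carbon as its single change. For the measured compounds named here, no two measured compounds differ in one place only, so nothing measured yet shows the size of this exchange. In this assay a modest move towards stronger inhibition is expected, with a 2.7-fold lower number from compound 1 to compound 3 (0.42 log units; beyond the scatter) as the estimate and a result inside the scatter quite possible. For compound 3 the estimated value is 18000 nM with 5000 nM to 55000 nM as the expected range.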

Compound 3, half-maximal inhibitory concentration: 2210 nM
Compound 3: middle estimate off by 8.1-fold (0.91 log units), on the high side, outside the stated range (below it).
By their numbers in this assay, from the lowest: compound 3; then compounds 2 and 1 (each within the scatter of the next).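

At this position, on an aromatic carbon ortho to a methoxy group, the exchange of chloro for amino is far from a small adjustment: in this assay it brings a 22-fold lower number from compound 1 to compound 3 (1.34 log units; beyond the scatter) and counts as a large step. This is the first single-place change among the compounds shown, and it reveals that this one position can by itself move inhibition well beyond the scatter, which compound 1 and compound 2 could not show. Nothing available accounts for the size of this step.

The compounds shown leave open whether amino is special here or whether other groups at this position, such as hydroxy, methylamino or acetamido, would bring a similar step. They also leave open whether amino would bring such a step elsewhere on this aromatic ring.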